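This account rests on a few compounds, and the source may have more. Where it says the series, first, only, none or still open, it means among the compounds named here.

Measured compounds in an ADME assay on cells (Homo sapiens) for cytotoxicity, read by polymerase chain reaction, with a stated time of 3 days; a lower number here means that less compound is tolerated, a higher number that more compound is tolerated:
compound 1 `Cc1nc(NC(C)(C)C)nc(N[C@@H]2C[C@H](CO)[C@@H](O)[C@H]2O)c1-c1nc2ccccc2s1` gives 12000 nM.
compound 2 `Cc1nc(NCCCC(F)(F)F)nc(N[C@@H]2C[C@H](CO)[C@@H](O)[C@H]2O)c1-c1nc2ccccc2s1` gives 3000 nM.
compound 3 `Cc1nc(NCc2cccnc2)nc(N[C@@H]2C[C@H](CO)[C@@H](O)[C@H]2O)c1-c1nc2ccccc2s1` gives 5000 nM.

Compound 3 stands second highest of the three numbers; its nearest neighbour is compound 2, with a 1.7-fold higher number from compound 2 to compound 3 (0.22 log units; within the scatter), and the furthest is compound 1, with a 2.4-fold lower number from compound 1 to compound 3 (0.38 log units; beyond the scatter). The change to compound 4 `Cc1nc(NCc2ccncc2)nc(N[C@@H]2C[C@H](CO)[C@@H](O)[C@H]2O)c1-c1nc2ccccc2s1` is pyridin-4-yl in place of pyridin-3-yl on a saturated chain carbon bound to a nitrogen on an aromatic ring. For the measured compounds named here, none of the measured steps tests this change directly: a 4.0-fold lower number from compound 1 to compound 2 (0.60 log units; beyond the scatter) and a 2.4-fold lower number from compound 1 to compound 3 (0.38 log units; beyond the scatter) both replace the tert-butyl group on the ring nitrogen, while a 1.7-fold higher number from compound 2 to compound 3 (0.22 log units; within the scatter) exchanges the whole group on the chain carbon and stays within the scatter. The ring system and its hetero atom count are unchanged, only the point of attachment moves, so no step beyond the scatter in this assay is expected in either direction. Compound 4 is therefore expected to give 5000 nM, with a range of 2500 nM to 10000 nM, meaning no change at the digits printed from compound 3 to compound 4 (within the scatter) as an estimate.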

Compound 4, half-maximal cytotoxic concentration: 7000 nM
Estimate against measurement, compound 4: 1.4-fold (0.15 log units) below; measured number inside the range.
By their numbers in this assay, from the lowest: compounds 2, 3, 4 and 1 (each within the scatter of the next, the first and the last beyond it).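

In this assay the shift from pyridin-3-yl to pyridin-4-yl on the saturated chain carbon gives a 1.4-fold higher number from compound 3 to compound 4 (0.15 log units; within the scatter) and so does not separate the two pyridine isomers. Set against the earlier steps, the pyridin-4-yl group stands clear of the 3,3,3-trifluoropropyl group with a 2.3-fold higher number from compound 2 to compound 4 (0.37 log units; beyond the scatter) and cannot be told apart from the tert-butyl reference on the ring nitrogen with a 1.7-fold lower number from compound 1 to compound 4 (0.23 log units; within the scatter), whereas the pyridin-3-yl compound was separated from that reference but not from the trifluorinated chain. No measurement at hand accounts for these differences.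

A pyridin-2-yl or plain phenyl group at the same place would show whether the ring nitrogen counts at all in this assay as a read on tolerated compound. Also open, from the compounds shown here alone, is how a longer chain carrying the pyridine would read.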